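Methoxy placement on the benzylamide of compound 3

The source may report more compounds than this note shows. Statements on the series, on what has been measured and on what is new or still open speak of the compounds shown alone.

Three amides on the shared core differ only in the group on a saturated chain carbon bound to an amide-type nitrogen. Compound 1 `CC(C)c1c(C(=O)NCC2CCCCC2)nn(-c2ccc(F)cc2)c1OC[C@@H](O)C[C@@H](O)CC(=O)O` gives 17 nM in an assay on microsomes from liver for inhibition of 3-hydroxy-3-methylglutaryl-coenzyme A reductase (Rattus norvegicus); a lower number here means a stronger inhibitor, a higher number a weaker inhibitor. Compound 2 `Cc1ccccc1CNC(=O)c1nn(-c2ccc(F)cc2)c(OC[C@@H](O)C[C@@H](O)CC(=O)O)c1C(C)C` gives 17 nM in this assay, with the step of no change at the digits printed from compound 1 to compound 2 (within the scatter). Compound 3 `COc1ccc(CNC(=O)c2nn(-c3ccc(F)cc3)c(OC[C@@H](O)C[C@@H](O)CC(=O)O)c2C(C)C)cc1` gives 12 nM in this assay, the smallest of the three numbers, but the steps of a 1.4-fold lower number from compound 1 to compound 3 (0.15 log units; within the scatter) and a 1.4-fold lower number from compound 2 to compound 3 (0.15 log units; within the scatter) both sit within the scatter, so no order among the three can be read from them.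

Compound 4 `COc1cccc(CNC(=O)c2nn(-c3ccc(F)cc3)c(OC[C@@H](O)C[C@@H](O)CC(=O)O)c2C(C)C)c1` has not yet been measured. Its difference from compound 3 is 3-methoxyphenyl in place of 4-methoxyphenyl on a saturated chain carbon bound to an amide-type nitrogen. The measured steps that bear on this are the two introducing the 4-methoxyphenyl, a 1.4-fold lower number from compound 1 to compound 3 (0.15 log units; within the scatter) and a 1.4-fold lower number from compound 2 to compound 3 (0.15 log units; within the scatter), and the exchange of cyclohexyl for 2-methylphenyl, no change at the digits printed from compound 1 to compound 2 (within the scatter); all three are flat. Among the measured compounds shown here, no measured compound carries a 3-methoxyphenyl, so the move of the methoxy has no direct precedent. For the measured compounds named here, every change at this place so far has stayed within the scatter. The step of a 1.3-fold higher number from compound 3 to compound 4 (0.10 log units; within the scatter) is therefore expected to be small in this assay, in no clear direction. Compound 4 is estimated at 15 nM in this assay, with a range of 7 nM to 35 nM.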

Compound 4, half-maximal inhibitory concentration: 16 nM
Compound 4: the middle estimate sits 1.1-fold (0.03 log units) below what was measured; measured number inside the range.
By their numbers in this assay, from the lowest: compounds 3, 4, 1 and 2 (each within the scatter of the next).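

In this assay, among the compounds shown here, the only pair here that keeps the same atoms and changes how they are joined, the 4-methoxyphenyl and the 3-methoxyphenyl, gives a flat reading (a 1.3-fold higher number from compound 3 to compound 4 (0.12 log units; within the scatter)), so moving the methoxy within this ring has no resolvable effect on the number. For the compounds shown here, the 3-methoxyphenyl also reads level with the 2-methylphenyl (a 1.1-fold lower number from compound 2 to compound 4 (0.03 log units; within the scatter)) and with the cyclohexyl (a 1.1-fold lower number from compound 1 to compound 4 (0.03 log units; within the scatter)), which extends the flat picture on a saturated chain carbon bound to an amide-type nitrogen to four groups, with no compound among them going against it. No supporting data are available to explain this flatness.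

The compounds shown leave open whether the flat reading holds when the ring on this chain carbon carries an amine, a carboxylic acid, a hydroxyl or a nitrile in place of the methoxy. They also leave open whether it survives a longer chain between the amide nitrogen and the ring, since every group here sits on the single saturated chain carbon.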